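Shortening the ester chain on the shared core: compound 4

The source may hold more compounds than are shown below. What is called first, only, known or untested is meant among the compounds shown, and "the series" means these compounds.

Measured so far:
compound 1, `CCOC(=O)C1=C(C)N(c2ccccc2)C=CC1c1ccccc1`; in a functional assay, tested at 100 ug/mL (on this read-out lower numbers stand for a stronger effect and higher numbers for a weaker effect at the one concentration tested), compound 1 gives -21.5%
compound 2, `CCOC(=O)C1=C(C)N(c2ccc(F)cc2)C=CC1c1ccccc1`; compound 2 gives -25.7%
compound 3, `CCOC(=O)C1=C(C)N(c2ccc(Br)cc2)C=CC1c1ccccc1`; compound 3 gives -18.7%

Compound 1 stands second highest of the three numbers. Its nearest neighbour is compound 3, a number 2.8 percentage points higher from compound 1 to compound 3 (within the scatter); its furthest is compound 2, a number 4.2 percentage points lower from compound 1 to compound 2 (within the scatter); the remaining pair gives a number 7 percentage points higher from compound 2 to compound 3 (within the scatter). All three values sit together, and none of the steps reaches beyond the scatter, so the three compounds cannot be ordered.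

Compound 4, `COC(=O)C1=C(C)N(c2ccccc2)C=CC1c1ccccc1`, differs from compound 1 by hydrogen in place of methyl on a saturated chain carbon bound to an oxygen next to a carbonyl group, that is ethoxycarbonyl to methoxycarbonyl. Within the data shown here, none of the measured steps touches this part of the molecule: each of them changes a substituent on an aromatic carbon of the ring on nitrogen, and each stayed within the scatter. Among the measured compounds shown here, there is no direct precedent for the ester change, so the expectation rests only on the flat behaviour of the series so far. The step expected is a number 0.5 percentage points higher from compound 1 to compound 4 (within the scatter), not beyond the scatter. Compound 4 is therefore estimated at -21%, with an expected range from -36% to -6%.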

Compound 4, a percentage reported as activity, at one concentration (the size of the read-out at that concentration, not a potency): -25.9%
Compound 4: the middle estimate sits 4.9 percentage points above what was measured; the range from low to high includes it.
By their numbers in this assay, from the lowest: compounds 4, 2, 1 and 3 (each within the scatter of the next).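

Ethoxycarbonyl to methoxycarbonyl is the only change shown that lies outside the ring on nitrogen, and in this assay the step is a number 4.4 percentage points lower from compound 1 to compound 4 (within the scatter). Removing this one carbon from the ester chain therefore leaves the read-out as flat as the fluoro and bromo changes on the aromatic carbon did, so the series now has a second site where a single change stays within the scatter, though this rests on one pair alone. No evidence is available on the reason for this result.

Going by these compounds, whether a carboxylic acid, an amide or a longer chain such as butyl at this place would move the read-out beyond the scatter remains open. Also open, on these data alone, is whether methoxycarbonyl behaves the same way alongside the fluoro of compound 2 or the bromo of compound 3.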